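From 4-methylphenyl to 4-chlorophenyl on the shared core

The source may report more compounds than this note shows. Statements on the series, on what has been measured and on what is new or still open speak of the compounds shown alone.

Compound 1 `O=C1COc2ccc(-c3cnc(Cl)c(NS(=O)(=O)c4ccc(F)cc4)c3)cc2N1C1CCCCC1`: 14300 nM
Compound 2 `Cc1ccc(N2C(=O)COc3ccc(-c4cnc(Cl)c(NS(=O)(=O)c5ccc(F)cc5)c4)cc32)cc1`: 32300 nM

In a functional assay on HeLa cells (Homo sapiens) for antiproliferative activity, read by MTT assay, with a stated time of 72 h (a lower number here means a stronger inhibitor, a higher number a weaker inhibitor), compound 2 stands highest of the two at 32300 nM, making it the weaker inhibitor of the pair. Compound 3 `O=C1COc2ccc(-c3cnc(Cl)c(NS(=O)(=O)c4ccc(F)cc4)c3)cc2N1c1ccc(Cl)cc1` keeps the shared core and differs from compound 2 in one place: chloro in place of methyl on an aromatic carbon. Within the data shown here, only one measured step touches this part of the structure: a 2.3-fold higher number from compound 1 to compound 2 (0.35 log units; beyond the scatter), a modest change that replaced cyclohexyl with 4-methylphenyl outright. Among the measured compounds shown here, no measured pair compares chloro with methyl, so that step gives no direction for this swap. No step beyond the scatter is therefore expected in this assay. The expected change is a 1.2-fold lower number from compound 2 to compound 3 (0.08 log units; within the scatter). Compound 3 is estimated at 27000 nM, with an expected range of 11000 nM to 60000 nM.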

Compound 3, half-maximal inhibitory concentration: > 40000 nM
Compound 3: no number, only a limit; the forecaster's own chance of this, stated with the estimate: 10%; middle value at least 1.4-fold (0.17 log units) from the limit.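

Compound 3 gives no number in this assay, only a limit: the limit of > 40000 nM in this assay, at which 1 of the 3 values shown sits. Chloro in place of methyl on the aromatic carbon gives an at least 1.2-fold higher number from compound 2 to compound 3 (0.09 log units; that floor lies within the scatter), so this swap has no known size and no firm direction. Replacing cyclohexyl on the amide-type nitrogen with 4-chlorophenyl gives an at least 2.7-fold higher number from compound 1 to compound 3 (0.44 log units; beyond the scatter), which sits alongside a 2.3-fold higher number from compound 1 to compound 2 (0.35 log units; beyond the scatter): both substituted phenyl groups shown at this position read as weaker than cyclohexyl.

The compounds shown leave open how far compound 3 lies past its limit, and so whether chloro and methyl truly differ at this position. They also leave open whether an unsubstituted phenyl, a 4-methoxyphenyl or a short chain such as ethyl on that nitrogen would give a lower number than cyclohexyl.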